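Series notes: pyridinyloxy substitution on the core of compound 1

The source may report more compounds than this note shows. Statements on the series, on what has been measured and on what is new or still open speak of the compounds shown alone.

For the measured compounds named here, compound 1 `CCOc1cccnc1Nc1cccc(C)n1` gives the lowest number of the three measured so far: in an assay on Ltk cells with metabotropic glutamate receptor 5 (Homo sapiens) as the target, read by fluorescence and calcium flux (a lower number here means a stronger inhibitor, a higher number a weaker inhibitor), compound 1 gives 40 nM. Compound 2 `CCNc1cccnc1Nc1cccc(C)n1` gives 3000 nM in this assay, and compound 3 `CCOc1c(C)ccnc1Nc1cccc(C)n1` gives 2700 nM. Both steps away from compound 1 are large: a 75-fold higher number from compound 1 to compound 2 (1.88 log units; beyond the scatter) with ethylamino in place of ethoxy on an aromatic carbon, and a 68-fold higher number from compound 1 to compound 3 (1.83 log units; beyond the scatter) with methyl in place of hydrogen on an aromatic carbon.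

Compound 4 `CCOc1cc(Oc2cccnc2)cnc1Nc1cccc(C)n1` differs from compound 1 by (pyridin-3-yl)oxy in place of hydrogen on an aromatic carbon. Going by the values given here, of the measured steps, only the one from compound 1 to compound 3 concerns a substitution on the same ring, and it was large; no measured step places a group at this carbon or a group of this size anywhere on the core. The step from compound 1 to compound 3 is therefore taken as a warning rather than a direct model. For compound 4 a weaker number than compound 1 is expected, estimated as a 7.5-fold higher number from compound 1 to compound 4 (0.88 log units; beyond the scatter), with wide uncertainty. The estimate for compound 4 in this assay is 300 nM, within a range of 50 nM to 2500 nM.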

Compound 4, half-maximal inhibitory concentration: 18 nM
For compound 4 the middle estimate is 17-fold (1.22 log units) above the measured one; the measured number lies below the stated range.
By their numbers in this assay, from the lowest: compound 4; then compound 1; then compounds 3 and 2 (each within the scatter of the next).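

At the carbon two atoms from the ring nitrogen and para to the (6-methylpyridin-2-yl)amino group, the core of compound 1 accepts a far larger group than the methyl of compound 3: in this assay, (pyridin-3-yl)oxy gives a 2.2-fold lower number from compound 1 to compound 4 (0.35 log units; beyond the scatter) and is the first change shown that lowers the number. The step is modest, but it shows that substitution on this ring need not cost activity, and the large loss seen with compound 3, substituted at a different carbon, does not carry over to this one. Nothing available explains this gain.

Open, going by these compounds, is whether a phenoxy group or a smaller methoxy group at this carbon would give a similar number. Also open, on these data alone, is whether an amine on the added pyridine ring would be accepted, and whether ethylamino in place of ethoxy would be as costly with the (pyridin-3-yl)oxy group present.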